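Bromo in place of hydrogen on the pendant phenyl

The source may report more compounds than this note shows. Statements on the series, on what has been measured and on what is new or still open speak of the compounds shown alone.

Measured compounds:
compound 1, `O=C(Nc1ccc(Oc2ccnc3[nH]ccc23)cc1)c1cc(-c2ccc(C(F)(F)F)cc2)ncn1`, 2160 nM
compound 2, `O=C(Nc1ccc(Oc2ccnc3[nH]ccc23)cc1)c1cc(-c2ccccc2)ncn1`, 240 nM

In a functional assay on PC-3 cells (Homo sapiens) for cytotoxicity, read by MTT assay, with a stated time of 72 h (on this read-out lower numbers stand for stronger inhibition and higher numbers for weaker inhibition), compound 2 gives the lowest of the two numbers, and compound 1 is the nearest, with a 9.0-fold lower number from compound 1 to compound 2 (0.95 log units; beyond the scatter) separating the pair. Compound 3, `O=C(Nc1ccc(Oc2ccnc3[nH]ccc23)cc1)c1cc(-c2ccc(Br)cc2)ncn1`, has not been measured. It differs from compound 2 by bromo in place of hydrogen on an aromatic carbon, on an aromatic carbon of a six-membered aromatic ring of carbon only, para to a large group; read one bond further out, phenyl becomes 4-bromophenyl. Among the compounds with values here, only one measured step bears on this position: the removal of trifluoromethyl from that same carbon gave a 9.0-fold lower number from compound 1 to compound 2 (0.95 log units; beyond the scatter), a modest step beyond the scatter. Bromo is a single heavy atom rather than trifluoromethyl, so the comparison is loose. A step back toward a higher number is expected for compound 3, of size a 2.7-fold higher number from compound 2 to compound 3 (0.43 log units; beyond the scatter). Compound 3 is therefore estimated at 650 nM, with a range from 200 nM to 2500 nM.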

Compound 3, half-maximal inhibitory concentration: 2610 nM
For compound 3 the middle estimate is 4.0-fold (0.60 log units) below the measured one; measured number above the stated range.
By their numbers in this assay, from the lowest: compound 2; then compounds 1 and 3 (each within the scatter of the next).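

Placing bromo on the same carbon gives an 11-fold higher number from compound 2 to compound 3 (1.04 log units; beyond the scatter) in this assay, so the loss seen earlier is not peculiar to trifluoromethyl: a single bromine atom on this carbon is enough to produce a large step away from the unsubstituted phenyl of compound 2. Exchanging one group for the other gives a 1.2-fold higher number from compound 1 to compound 3 (0.08 log units; within the scatter) and stays within the scatter, so this assay does not separate the two substituted compounds, and on this evidence the bare phenyl stands apart from both. Nothing available here accounts for why either group has this effect.

Both groups shown at this position contain halogen, so it remains open how a methoxy group, an amine or a hydroxyl group would fare there. Also open, on these data alone, is whether bromo would give a similar step on another carbon of the same ring.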